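A few compounds are considered here, and "the series" means these few. Any claim that something is new, unique, unknown or untested is made for them only; others in the source may bear on it.

In a functional assay on AGS cells (Homo sapiens) for antiproliferative activity, read by MTT assay, with a stated time of 48 h (on this read-out lower numbers stand for stronger inhibition of growth and higher numbers for weaker inhibition of growth), compound 1 (`COc1ccc(N(C)c2ncnc3c2ncn3Cc2cc(OC)cc(OC)c2)cc1`) gives > 100000 nM, which is a limit of the assay. Compound 2 (`COc1ccc(N(C)c2ncnc3c2ncn3Cc2cc(OC)c(OC)c(OC)c2)cc1`) gives > 100000 nM, also only a limit, so its standing has no number. Compound 3 (`COc1ccc(N(C)c2nc(Cl)nc3c2ncn3Cc2cc(OC)c(OC)c(OC)c2)cc1`) gives 85000 nM. The methoxy change is a step that the two limits leave unreadable from compound 1 to compound 2. The chloro change is an at least 1.1-fold lower number from compound 2 to compound 3 (0.07 log units; that floor lies within the scatter), and this lies within the scatter.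

Compound 4 (`COc1cc(Cn2cnc3c(Cl)ncnc32)cc(OC)c1OC`) differs from compound 2 as follows: chloro in place of (4-methoxyphenyl)(methyl)amino on an aromatic carbon. In words, this is chloro in place of (4-methoxyphenyl)(methyl)amino on an aromatic carbon. Among the compounds with values here, no measured step makes this exchange. The nearest is the chloro step, an at least 1.1-fold lower number from compound 2 to compound 3 (0.07 log units; that floor lies within the scatter), so only a modest move toward stronger inhibition in this assay is expected, and a further limit remains possible. The expected change is an at least 1.6-fold lower number from compound 2 to compound 4 (0.22 log units; that floor lies within the scatter). For compound 4 the estimate is 60000 nM, with an expected range of 20000 nM to 150000 nM.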

Compound 4, concentration for 50% growth inhibition: > 50000 nM
Compound 4: no number, only a limit; the forecaster's own chance of this, stated with the estimate: 40%; the middle value is on the limit's open side.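

Compound 2 and compound 4 both stand only at limits in this assay, so the step between them cannot be read. The compounds shown leave open the size and direction of the effect of chloro in place of (4-methoxyphenyl)(methyl)amino.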